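Reversing the enone linker on a fused core

The compounds below may be only part of what the source reports. "The series", "measured", "known", "first", "only" and "open" are said of these compounds alone.

Compound 3 `COc1ccc(-c2cc(/C=C/C(=O)c3ccc(C)cc3)nc3cc(-c4ccccc4)nn23)cc1OC` sits at the weak end of three closely spaced numbers: in a functional assay on A549 cells (Homo sapiens) for antiproliferative activity, read by MTT assay, with a stated time of 24 h (on this read-out lower numbers stand for stronger inhibition and higher numbers for weaker inhibition), compound 3 gives 17200 nM. Compound 1 `COc1ccc(-c2cc(C(=O)/C=C/c3cc(OC)c(OC)c(OC)c3)nc3cc(-c4ccccc4)nn23)cc1OC` gives 15400 nM, and compound 2 `COc1ccc(-c2cc(/C=C/C(=O)c3ccccc3)nc3cc(-c4ccccc4)nn23)cc1OC` gives 10700 nM. Within the data shown here, the only single-point step among them, a 1.6-fold higher number from compound 2 to compound 3 (0.21 log units; within the scatter), shows that adding the methyl changed little. Compound 4 `COc1ccc(-c2cc(C(=O)/C=C/c3ccc(C)cc3)nc3cc(-c4ccccc4)nn23)cc1OC` has the same atoms as compound 3, joined differently: (2-(4-methylphenyl)ethenyl)carbonyl in place of 2-((4-methylphenyl)carbonyl)ethenyl on an aromatic carbon. Among the measured compounds shown here, no measured step isolates this reversal of the carbonyl and ethenyl order. The nearest hint is that compound 1, which carries the carbonyl next to the shared core as compound 4 does, and compound 3, which carries it on the far aryl ring, sit within the scatter of each other, though their aryl groups also differ. On that basis the step of a 1.1-fold lower number from compound 3 to compound 4 (0.06 log units; within the scatter) is expected to stay within the scatter. Compound 4 is therefore estimated at 15000 nM in this assay, with a likely range from 7000 nM to 35000 nM.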

Compound 4, half-maximal inhibitory concentration: 22200 nM
Estimate against measurement, compound 4: 1.5-fold (0.17 log units) below; low and high end bracket the measured number.
By their numbers in this assay, from the lowest: compounds 2, 1, 3 and 4 (each within the scatter of the next, the first and the last beyond it).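

Turning the linker around at this position gives a 1.3-fold higher number from compound 3 to compound 4 (0.11 log units; within the scatter) in this assay so the order of carbonyl and ethenyl, now tested directly, makes no readable difference here. With the carbonyl order held fixed, the 4-methylphenyl group in place of 3,4,5-trimethoxyphenyl gives a 1.4-fold higher number from compound 1 to compound 4 (0.16 log units; within the scatter) and so the number does not separate these two aryl groups either. The only step past the scatter is a 2.1-fold higher number from compound 2 to compound 4 (0.32 log units; beyond the scatter) and it is modest; it combines the reversal with the added methyl, and neither change alone clears the scatter in the steps shown.

On these data alone, whether an amine or a carboxylic acid in place of that methyl would shift the number in either linker order remains open. The data offer no measured explanation for these small shifts.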